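Phenyl Replacing a Hydroxyalkyl Group on the Amine

This account rests on a few compounds, and the source may have more. Where it says the series, first, only, none or still open, it means among the compounds named here.

Measured compounds:
Compound 1, `OCCCNCc1nc2c(OCC3CCCCC3)cccc2[nH]1` — in an assay on cells for inhibition of interleukin-5 receptor subunit alpha (Mus musculus), read by WST assay, with a stated time of 48 h, in the presence of a further agent that is not named here (a higher number here means a weaker inhibitor, a lower number a stronger inhibitor), compound 1 gives 28500 nM.
Compound 2, `OCCCCNCc1nc2c(OCC3CCCCC3)cccc2[nH]1` — in this assay compound 2 gives 30000 nM.
Compound 3, `CC(C)(CO)NCc1nc2c(OCC3CCCCC3)cccc2[nH]1` — in this assay compound 3 gives 27500 nM.

All three share the same core and differ only in the group carried by the amine nitrogen. Compound 3 has the lowest of the three numbers, but that means little: the step of a 1.0-fold lower number from compound 1 to compound 3 (0.02 log units; within the scatter) and the step of a 1.1-fold lower number from compound 2 to compound 3 (0.04 log units; within the scatter) are both within the scatter, as is the step of a 1.1-fold higher number from compound 1 to compound 2 (0.02 log units; within the scatter). The three compounds are therefore indistinguishable on these numbers.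

Compound 4, `c1ccc(NCc2nc3c(OCC4CCCCC4)cccc3[nH]2)cc1`, takes the next step: phenyl in place of 1-(hydroxymethyl)-1-methylethyl on an amine nitrogen. The measured steps bear on this only loosely. Each of them exchanged one hydroxy-bearing chain for another on the same nitrogen, and none moved the number beyond the scatter, so the amine substituent has so far shown no influence. Among the measured compounds shown here, the change to compound 4 is of a different kind, removing the hydroxy group and bringing in an aromatic ring, and no measured pair covers it. The expectation is therefore a step of a 1.1-fold lower number from compound 3 to compound 4 (0.04 log units; within the scatter) in this assay, that is, none beyond the scatter, with wide uncertainty. Compound 4 is estimated at 25000 nM, in a range from 8000 nM to 80000 nM.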

Compound 4, half-maximal inhibitory concentration: > 30000 nM
Compound 4 was reported as a limit (the forecaster's own chance of this, stated with the estimate: 20%); middle value at least 1.2-fold (0.07 log units) away from the limit.
By their numbers in this assay, from the lowest: compounds 3, 1 and 2 (each within the scatter of the next).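

Compound 4, which carries phenyl on the amine nitrogen, is reported in this assay only as a limit, > 30000 nM. The steps that can be read are an at least 1.0-fold higher number from compound 3 to compound 4 (0.03 log units; that floor lies within the scatter) and an at least 1.0-fold higher number from compound 1 to compound 4 (0.02 log units; that floor lies within the scatter). The earlier compounds only exchanged one hydroxy-bearing chain for another and all gave exact values, whereas this first change to an aromatic ring with no hydrogen-bond donor or acceptor gives no sign of a lower number, and how much higher the true number may be stays unknown: the limit of > 30000 nM in this assay, at which 1 of the 4 values shown sits.

The remaining step, a number no lower from compound 2 to compound 4 (the limit leaves the size open), cannot be read, and the compounds shown leave open whether a benzyl group or a hydroxyphenyl group on the amine nitrogen would give a number that can be read, which would separate the loss of the hydroxy group from the arrival of the ring. They also leave open whether any group on this nitrogen, such as a chain ending in a carboxylic acid or an amine, can move the number beyond the scatter in either direction.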